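Changing One Phenyl Group on Compound 1

This account rests on a few compounds, and the source may have more. Where it says the series, first, only, none or still open, it means among the compounds named here.

In an ADME assay on L6 cells (Rattus norvegicus) for cytotoxicity, read by resazurin assay (on this read-out lower numbers stand for stronger inhibition and higher numbers for weaker inhibition), compound 1 (`N=C(N)c1ccc2[nH]c(-c3ccc4nc(-c5ccccc5F)[nH]c4c3)nc2c1`) gives 26.8 ug/mL as its reading, and compound 2 (`CC(C)(C)c1cccc(-c2nc3ccc(-c4nc5cc(C(=N)N)ccc5[nH]4)cc3[nH]2)c1O`) gives 13.4 ug/mL as its reading. These two numbers lie within the usual scatter of repeated measurements, so compound 1 stands level with compound 2 and the pair cannot be ranked.

Compound 3 (`COc1cc(OC)cc(-c2nc3ccc(-c4nc5cc(C(=N)N)ccc5[nH]4)cc3[nH]2)c1`) keeps the core of compound 1 and changes a single group. A 3,5-dimethoxyphenyl replaces the 2-fluorophenyl on an aromatic carbon between two ring nitrogen atoms, and the count of the change reads 3,5-dimethoxyphenyl in place of 2-fluorophenyl on an aromatic carbon in full.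

Among the measured compounds shown here, no measured pair shows a change of this kind, so any forecast is rough. For the measured compounds named here, the only guide is that the reading of compound 2 at 13.4 ug/mL falls within the scatter of compound 1. In this assay the estimated 1.5-fold lower number from compound 1 to compound 3 (0.17 log units; within the scatter) is therefore expected to stay within the scatter, with only a slight lean toward a lower number. The estimate for compound 3 is 18 ug/mL (expected range 6 ug/mL to 50 ug/mL).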

Compound 3, half-maximal inhibitory concentration: 25.5 ug/mL
Beside the measured number, compound 3's estimate is 1.4-fold (0.15 log units) below it, within the range that was stated.
By their numbers in this assay, from the lowest: compounds 2, 3 and 1 (each within the scatter of the next).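

Among the compounds shown here, compound 1 and compound 3 form the first pair here that differs in only one place, so this is the first direct look at what a change on this aromatic carbon, between two ring nitrogen atoms, does in this assay. The step from 2-fluorophenyl to 3,5-dimethoxyphenyl reads a 1.1-fold lower number from compound 1 to compound 3 (0.02 log units; within the scatter), so a group with 10 heavy atoms and 2 hydrogen-bond acceptors can take the place of one with 7 heavy atoms and 0 hydrogen-bond acceptors while the two readings stay indistinguishable. The pair therefore shows that this particular exchange of one phenyl group for another leaves no measurable mark on this read-out, although no measurement on hand offers an explanation for that.

From the compounds shown here alone, both groups are six-membered aromatic rings of carbon, so it remains open whether the reading would also hold with something other than such a ring at this position, for example an amine, a carboxylic acid or a longer alkyl chain. Going by these compounds, it is also open whether a single methoxy group, or a fluorine at another place on the phenyl ring, would read any differently.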